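From fluorine to hydroxyl on the pendant aryl ring

The source may hold more compounds than are shown below. What is called first, only, known or untested is meant among the compounds shown, and "the series" means these compounds.

Compound 1, `COc1ccc(-c2ccc3c(c2)C(=O)C(=O)N3c2ccc(OC)cc2)cc1`: > 10000 nM
Compound 2, `COc1ccc(-c2ccc3c(c2)C(=O)C(=O)N3Cc2ccc(C#N)cc2)cc1`: 380 nM
Compound 3, `COc1ccc(CN2C(=O)C(=O)c3cc(-c4ccc(F)cc4)ccc32)cc1`: 240 nM

In a functional assay on K562 cells (Homo sapiens) for antiproliferative activity, read by MTT assay, with a stated time of 48 h (on this read-out higher numbers stand for weaker inhibition and lower numbers for stronger inhibition), compound 1 gives > 10000 nM, which is a limit of the assay and not a number. Compound 2 gives 380 nM, and compound 3 gives 240 nM. The values of compound 2 and compound 3 lie within the usual scatter of each other, so no order can be drawn between them. Among the measured compounds shown here, the one step that can be sized, an at least 26-fold lower number from compound 1 to compound 2 (1.42 log units; beyond the scatter), concerns the group on the ring nitrogen of the shared core, not the pendant aryl ring, and its size rests on (the limit of > 10000 nM in this assay, at which 1 of the 3 values shown sits).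

Compound 4, `COc1ccc(CN2C(=O)C(=O)c3cc(-c4ccc(O)cc4)ccc32)cc1`, differs from compound 3 by hydroxy in place of fluoro on an aromatic carbon. For the measured compounds named here, none of the measured steps touches this pendant ring, so the change from compound 3 to compound 4 has no direct counterpart among the measured steps. The expectation is therefore a step of a size that stays within the scatter in this assay, in no fixed direction: the expected step is a 1.3-fold higher number from compound 3 to compound 4 (0.10 log units; within the scatter). Compound 4 is thus expected to give 300 nM, with a range from 100 nM to 1000 nM.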

Compound 4, half-maximal inhibitory concentration: 60 nM
Beside the measured number, compound 4's estimate is 5.0-fold (0.70 log units) above it; the whole stated range lies above it.
By their numbers in this assay, from the lowest: compound 4; then compounds 3 and 2 (each within the scatter of the next). At a limit, above all of these: compound 1.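

In this assay, the pendant aryl ring proves to be a place where a single-atom change can be read: a 4.0-fold lower number from compound 3 to compound 4 (0.60 log units; beyond the scatter). Among the compounds shown here, the earlier compounds could not show this, as the only sized step among them concerned the group on the ring nitrogen, so this is the first evidence that the para substituent on the pendant ring also affects the antiproliferative read-out. The swap from 4-fluorophenyl to 4-hydroxyphenyl adds one hydrogen-bond donor and one hydrogen-bond acceptor, but that count only describes the structures, and nothing measured here explains the lower number.

As far as these compounds go, with the group on the ring nitrogen held as in compound 3 and compound 4, only fluoro and hydroxy are seen at this place, so it remains open how an amine or a carboxylic acid there would read, and whether the hydroxy hydrogen itself matters. From the compounds shown here alone, it is also open whether the same swap would give a step of similar size with the 4-cyanobenzyl group of compound 2 on the ring nitrogen.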